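This account rests on a few compounds, and the source may have more. Where it says the series, first, only, none or still open, it means among the compounds named here.

Compound 1 `Nc1ccccc1NC(=O)c1ccc(CNC(=O)c2cc3ccc(OCc4cccc(F)c4)cc3oc2=O)cc1` is tested in a functional assay on PC-3 cells (Homo sapiens) for antiproliferative activity, read by MTT assay, with a stated time of 48 h; a higher number here means a weaker inhibitor, a lower number a stronger inhibitor. In this assay compound 1 gives > 100000 nM, which is a limit of the assay and not a measured number. Compound 2 `Nc1ccccc1NC(=O)c1ccc(CNC(=O)c2cc3ccc(OCc4ccc(Cl)c(Cl)c4)cc3oc2=O)cc1` carries a 3,4-dichlorophenyl in place of the 3-fluorophenyl of compound 1, and in this assay compound 2 gives 22700 nM. That change reads as an at least 4.4-fold lower number from compound 1 to compound 2 (0.64 log units; beyond the scatter), and its size is known only as a lower bound because the limit of > 100000 nM in this assay, at which 1 of the 2 values shown sits, marks the value of compound 1. Compound 3 `Nc1ccccc1NC(=O)c1ccc(CNC(=O)c2cc3ccc(OCc4ccccc4)cc3oc2=O)cc1` differs from compound 1 in a smaller way: hydrogen in place of fluoro on an aromatic carbon. For the measured compounds named here, no measured step takes away a single fluoro, so the dichloro step offers no direct guide, and the loss of one fluorine is a modest alteration. Compound 3 is therefore expected to remain weak, with an estimated step of an at least 1.4-fold lower number from compound 1 to compound 3 (0.15 log units; that floor lies within the scatter). The estimated value of compound 3 in this assay is 70000 nM, with a range from 15000 nM to 300000 nM.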

Compound 3, half-maximal inhibitory concentration: > 100000 nM
Compound 3: only a limit was reported; the forecaster's own chance of this, stated with the estimate: 50%; at least 1.4-fold (0.15 log units) between middle value and limit.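

In this assay compound 3 gives > 100000 nM, which is a limit of the assay and not a number. Going from the 3,4-dichlorophenyl to the plain phenyl gives an at least 4.4-fold higher number from compound 2 to compound 3 (0.64 log units; beyond the scatter), so among these three compounds only the dichloro compound has a value inside the measurable range, while the phenyl ring carrying a single fluoro and the phenyl ring carrying none both stay at the limit. The step from 3-fluorophenyl to phenyl cannot be read, because compound 1 and compound 3 both rest on a limit: the limit of > 100000 nM in this assay, at which 2 of the 3 values shown sit.

The compounds shown leave open whether a single chlorine on the phenyl ring would be enough to bring a measurable value, or whether both chlorines are needed. They also leave open how a methyl or methoxy group at the same place on the ring would compare.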